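The source may report more compounds than this note shows. Statements on the series, on what has been measured and on what is new or still open speak of the compounds shown alone.

Measured so far in an in vivo ADME assay on the whole organism (strain CD1) for pharmacokinetics, with Mus musculus as the target, at a dose of 30 mg/kg by the oral route; a higher number here means more compound in the circulation at the dose given, a lower number less compound in the circulation
- compound 1 `CCOC(=O)c1c(-c2cccc(-c3ccccc3)c2)[nH]c2cc(OC)ccc2c1=O` gives 230 nM
- compound 2 `CCOC(=O)c1c(-c2cccc(OC)c2)[nH]c2cc(OC)ccc2c1=O` gives 8000 nM
- compound 3 `CCCOc1cccc(-c2[nH]c3cc(OC)ccc3c(=O)c2C(=O)OCC)c1` gives 300 nM

Compound 3 stands level with compound 1, as a 1.3-fold higher number from compound 1 to compound 3 (0.12 log units; within the scatter) shows, and far under compound 2, as a 27-fold lower number from compound 2 to compound 3 (1.43 log units; beyond the scatter) shows. Compound 4 `CCOC(=O)c1c(-c2cccc(Oc3ccccc3)c2)[nH]c2cc(OC)ccc2c1=O` carries phenyl in place of propyl on an oxygen on an aromatic ring.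

The large 35-fold higher number from compound 1 to compound 2 (1.54 log units; beyond the scatter) and the step to compound 3 set the methoxy compound apart from the other two. Compound 1 and compound 3 carry different groups yet do not separate beyond the scatter. Among the measured compounds shown here, compound 4 therefore looks likelier to join them than compound 2, though no phenoxy compound has been measured. The expected change is a 1.2-fold lower number from compound 3 to compound 4 (0.06 log units; within the scatter), which would be no step beyond the scatter. For compound 4 the estimate is 260 nM, with an expected range of 70 nM to 1000 nM.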

Compound 4, maximal plasma concentration: 60 nM
Beside the measured number, compound 4's estimate is 4.3-fold (0.64 log units) above it; measured number outside the range, below it.
By their numbers in this assay, from the lowest: compound 4; then compounds 1 and 3 (each within the scatter of the next); then compound 2.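

The new number shows that the fall seen on going from methyl to propyl on this oxygen does not stop at propyl: phenyl lowers the number further in this assay (a 5.0-fold lower number from compound 3 to compound 4 (0.70 log units; beyond the scatter)), and the whole span from methyl to phenyl is large (a 130-fold lower number from compound 2 to compound 4 (2.12 log units; beyond the scatter)). Phenoxy in place of phenyl on the aromatic carbon also gives a lower number (a 3.8-fold lower number from compound 1 to compound 4 (0.58 log units; beyond the scatter)), so the added oxygen brings no return towards compound 2. Nothing at hand explains these drops. The compounds shown leave open how a chain ending in an amine or a carboxylic acid on this oxygen would read, and whether ethyl would fall nearer to methyl or to propyl.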